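A Methyl on the Phenethyl Terminus of Compound 2

A few compounds are considered here, and "the series" means these few. Any claim that something is new, unique, unknown or untested is made for them only; others in the source may bear on it.

Of the compounds shown here, two from this series have been measured in an assay on CHO cells for antagonist activity at transient receptor potential cation channel subfamily V member 1 (Homo sapiens), read by FLIPR; a lower number here means a stronger inhibitor, a higher number a weaker inhibitor. Compound 1 `CC(C(=O)NCc1ccc(C(F)(F)F)nc1-c1ccc(C(C)(C)C)cc1)c1ccc(NS(C)(=O)=O)c(F)c1` gives 0.5 nM in this assay, and compound 2 `CC(C(=O)NCc1ccc(C(F)(F)F)nc1CCc1ccccc1)c1ccc(NS(C)(=O)=O)c(F)c1` gives 1.4 nM. Going by the values given here, the one step between them, a 2.8-fold higher number from compound 1 to compound 2 (0.45 log units; beyond the scatter), sets compound 2 at the higher of the two numbers, with compound 1 the nearer and lower one. Compound 3 `Cc1ccc(CCc2nc(C(F)(F)F)ccc2CNC(=O)C(C)c2ccc(NS(C)(=O)=O)c(F)c2)cc1` has not yet been measured in this assay. It differs from compound 2 in one place: methyl in place of hydrogen on an aromatic carbon, at the end of the phenethyl group, giving 2-(4-methylphenyl)ethyl in place of phenethyl. Among the compounds with values here, no measured step touches this change; the only step available, a 2.8-fold higher number from compound 1 to compound 2 (0.45 log units; beyond the scatter), exchanges the whole aryl group rather than adding a methyl to it, and so gives little guidance. With nothing to point either way, compound 3 is expected to stay close to compound 2, a step of a 1.2-fold lower number from compound 2 to compound 3 (0.07 log units; within the scatter) that is not expected to exceed the scatter. Compound 3 is estimated at 1.2 nM, within a range from 0.4 nM to 4 nM.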

Compound 3, inhibition constant: 0.6 nM
Compound 3: the middle estimate sits 2.0-fold (0.30 log units) above what was measured, within the range that was stated.
By their numbers in this assay, from the lowest: compounds 1 and 3 (each within the scatter of the next); then compound 2.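

In this assay, going by these compounds alone, the methyl at the end of the phenethyl group gives a 2.3-fold lower number from compound 2 to compound 3 (0.37 log units; beyond the scatter), so this aromatic carbon, para to a large group, responds to the addition of a single carbon, which the exchange of the whole aryl group between the earlier compounds could not show. The new group also changes how the two aryl-bearing side chains compare: the step that replaces 4-(tert-butyl)phenyl with 2-(4-methylphenyl)ethyl is a 1.2-fold higher number from compound 1 to compound 3 (0.08 log units; within the scatter), so these two groups cannot be told apart in this assay, whereas the phenethyl group of compound 2 stood apart from 4-(tert-butyl)phenyl beyond the scatter. Nothing in the available data bears on how the added methyl produces this step.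

With one substituent at one position, the compounds shown leave open whether the step belongs to methyl itself or would also appear with a chlorine, a methoxy group or a longer chain such as ethyl or tert-butyl on the same carbon. They also leave open whether a methyl on another carbon of this ring, or a shorter or longer chain linking the ring to the core, would give a step of similar size.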